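Working notes: one-carbon extension of the amide chain

The source may hold more compounds than are shown below. What is called first, only, known or untested is meant among the compounds shown, and "the series" means these compounds.

Measured so far in a functional assay on NCI-H460 cells (Homo sapiens) for inhibition, read by MTT assay, with a stated time of 72 h; on this read-out lower numbers stand for stronger inhibition and higher numbers for weaker inhibition:
- compound 1 `O=C1Nc2ccccc2/C1=C\C(=O)c1cc(F)cc(F)c1` gives 13300 nM
- compound 2 `CC(=O)Nc1cccc(C(=O)/C=C2/C(=O)Nc3ccccc32)c1` gives 12300 nM
- compound 3 `O=C1Nc2ccccc2/C1=C\C(=O)c1ccccc1F` gives 8500 nM

All three share the same core and differ only in the substituted aryl ring attached to the ketone. Among the three numbers, compound 2 stands second highest. Its nearest neighbour is compound 1, whose number is slightly higher, and the furthest is compound 3, whose number is somewhat lower; both of these gaps lie within the usual scatter of this assay, so the three compounds cannot be ordered against each other on these data.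

The step under consideration goes from compound 2 to compound 4 `CCC(=O)Nc1cccc(C(=O)/C=C2/C(=O)Nc3ccccc32)c1`, which has not yet been measured. The change is methyl in place of hydrogen on a saturated chain carbon bound to a carbonyl carbon. Put another way, acetamido becomes propanoylamino; nothing else in the molecule moves.

Among the compounds with values here, no comparable step between measured compounds is available, so the expectation rests on the small size of the change alone. With only one carbon added on a saturated chain carbon bound to a carbonyl carbon, the step of a 1.1-fold lower number from compound 2 to compound 4 (0.05 log units; within the scatter) in this assay is expected to be small and not clearly beyond the scatter, in either direction. Compound 4 is therefore estimated at 11000 nM, with a plausible range from 5000 nM to 25000 nM.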

Compound 4, half-maximal inhibitory concentration: 10300 nM
Beside the measured number, compound 4's estimate is 1.1-fold (0.03 log units) above it; the measured number falls inside the stated range.
By their numbers in this assay, from the lowest: compounds 3, 4, 2 and 1 (each within the scatter of the next).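

The amide chain gives the series its first step that differs in one place, and in this assay methyl in place of hydrogen on a saturated chain carbon bound to a carbonyl carbon reads as a 1.2-fold lower number from compound 2 to compound 4 (0.08 log units; within the scatter) and so cannot be told apart from no difference. The earlier compounds shown here offered no such pair, whereas this step shows that, at this position, going from acetamido to propanoylamino leaves the number within the scatter, so one added carbon here neither clearly helps nor clearly harms in this read-out. No measured evidence bears on the reason for this result.

A longer chain such as butanoyl, a branched chain such as isobutyryl, or a chain ending in an amine or a carboxylic acid could read quite differently in this assay, and a single one-carbon step says nothing about them. The compounds shown also include no group at this position whose step lies beyond the scatter, so how far the number can move through changes at this chain remains open.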